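Changing the aryl tail of compound 3

The compounds below may be only part of what the source reports. "The series", "measured", "known", "first", "only" and "open" are said of these compounds alone.

Compound 1 `N[C@H](CN(C(=O)[C@@H]1C[C@H]1c1ccccc1)c1ccc(-c2ccccc2)cc1)C1CCCCC1`: 0.66 nM
Compound 2 `CC[C@H](C)[C@H](N)CN(C(=O)[C@@H]1C[C@H]1c1cccs1)c1ccc(-c2ccccc2)cc1`: 360 nM
Compound 3 `CC(C)C[C@H](N)CN(C(=O)[C@@H]1C[C@H]1c1ccccc1)c1ccc(-c2ccoc2)cc1`: 2000 nM

In a functional assay for agonist activity at G protein-coupled receptor 88 (Homo sapiens), read by HTRF and cAMP accumulation (on this read-out lower numbers stand for an effect already at smaller amounts and higher numbers for an effect only at larger amounts of compound), compound 1 gives 0.66 nM and compound 2 gives 360 nM, while compound 3 stands at the highest number of the three with 2000 nM, beyond the scatter from either. Compound 4 `CC(C)C[C@H](N)CN(C(=O)[C@@H]1C[C@H]1c1ccccc1)c1ccc(-c2cccc(C#N)c2)cc1` is not yet measured. It differs from compound 3 in one place only, (3-cyanophenyl in place of furan-3-yl on an aromatic carbon), so that a six-membered aromatic ring of carbon only takes the place of a five-membered aromatic ring with one hetero atom. Within the data shown here, no step between measured compounds shows this change on its own, and the other compounds differ in more than one place. The step of a 6.7-fold lower number from compound 3 to compound 4 (0.82 log units; beyond the scatter) is expected to go toward a lower number, of moderate size. Compound 4 is estimated at 300 nM, within 40 nM to 2500 nM.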

Compound 4, half-maximal effective concentration: 4500 nM
Compound 4: middle estimate off by 15-fold (1.18 log units), on the low side; the measured number lies above the stated range.
By their numbers in this assay, from the lowest: compound 1; then compound 2; then compound 3; then compound 4.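

In this assay, 3-cyanophenyl in place of furan-3-yl gives a 2.3-fold higher number from compound 3 to compound 4 (0.35 log units; beyond the scatter), a modest step that lies beyond the scatter. At this aromatic carbon, para to a large group, the six-membered ring of carbon only with its nitrile therefore does not bring the number down. The data shown give no reason for this step.

The change swaps the ring and adds the nitrile together, leaving the share of each open. As far as these compounds go, how a methoxy group or a fluorine on that ring would read also remains open.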